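A Benzyl Swap on the Amine of Compound 3

A few compounds are considered here, and "the series" means these few. Any claim that something is new, unique, unknown or untested is made for them only; others in the source may bear on it.

Values measured in a functional assay on MCF7 cells (Homo sapiens) for antiproliferative activity (a lower number here means a stronger inhibitor, a higher number a weaker inhibitor), so far:
- compound 1 `CCNCCCOc1ccc2cc(NC(=O)c3ccc(O)c(CC=C(C)C)c3)c(=O)oc2c1C` gives 980 nM 
- compound 2 `CC(C)=CCc1cc(C(=O)Nc2cc3ccc(OCCCNCC(N)=O)c(C)c3oc2=O)ccc1O` gives 1460 nM 
- compound 3 `CC(C)=CCc1cc(C(=O)Nc2cc3ccc(OCCCNC4CCCCC4)c(C)c3oc2=O)ccc1O` gives 1070 nM 

These three compounds share one core and differ only in the group on the amine nitrogen at the end of the chain. Compound 3 (1070 nM) lies within the scatter of both other compounds, so the numbers do not separate the three.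

The next compound is compound 4 `CC(C)=CCc1cc(C(=O)Nc2cc3ccc(OCCCN(C)Cc4ccccc4)c(C)c3oc2=O)ccc1O`, where benzyl(methyl)amino stands in place of cyclohexylamino on a saturated chain carbon, three bonds along the chain from an oxygen on an aromatic ring (benzyl(methyl)amino in place of cyclohexylamino on a saturated chain carbon, three bonds along the chain from an oxygen on an aromatic ring).

The closest evidence is the set of changes already made on that amine nitrogen. The value rises by a 1.1-fold higher number from compound 1 to compound 3 (0.04 log units; within the scatter) and falls by a 1.4-fold lower number from compound 2 to compound 3 (0.13 log units; within the scatter), while the remaining change gives a 1.5-fold higher number from compound 1 to compound 2 (0.17 log units; within the scatter). All three steps are within the scatter, so these swaps have left this assay essentially unmoved. Within the data shown here, none of the measured compounds carries a benzyl group, however, so the range is kept wide.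

No step beyond the scatter is expected, in either direction, and the estimated change is a 1.1-fold lower number from compound 3 to compound 4 (0.03 log units; within the scatter).

For compound 4 the expected value is 1000 nM, with an estimated range of 450 nM to 2200 nM.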

Compound 4, half-maximal inhibitory concentration: 11500 nM
For compound 4 the middle estimate is 12-fold (1.06 log units) below the measured one; measured number above the stated range.
By their numbers in this assay, from the lowest: compounds 1, 3 and 2 (each within the scatter of the next); then compound 4.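

In this assay, among these compounds, the amine nitrogen at the end of the chain turns out not to accept every group, as the earlier compounds had suggested: benzyl(methyl)amino gives an 11-fold higher number from compound 3 to compound 4 (1.03 log units; beyond the scatter), along with a 7.9-fold higher number from compound 2 to compound 4 (0.90 log units; beyond the scatter) and a 12-fold higher number from compound 1 to compound 4 (1.07 log units; beyond the scatter), all beyond the scatter, whereas ethyl, carbamoylmethyl and cyclohexyl on that nitrogen could not be told apart. Compound 4 differs from the other three in two countable ways at this place: its group carries an aromatic ring, and it has no hydrogen-bond donor, where cyclohexylamino has one. Nothing available here explains why the number rises so far.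

The swap changes two things at once, adding a methyl to the nitrogen and replacing the cyclohexyl with a benzyl, so the compounds shown cannot say which of the two goes with the weaker result. A plain benzylamino group would keep the hydrogen on the nitrogen while carrying the aromatic ring, and a cyclohexyl(methyl)amino group would do the reverse, so this pair would pull the two changes apart.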